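The source may hold more compounds than are shown below. What is called first, only, known or untested is meant among the compounds shown, and "the series" means these compounds.

Measured compounds in an assay on cells with melanin-concentrating hormone receptor 1 (Homo sapiens) as the target, read by radioligand binding; a lower number here means a stronger inhibitor, a higher number a weaker inhibitor:
compound 1 `CC(C)Oc1cccc2ccc(N)nc12` gives 437 nM
compound 2 `CCC(CC)C(C)Oc1cccc2ccc(N)nc12` gives 191 nM
compound 3 `CC(COC(C)(C)C)Oc1cccc2ccc(N)nc12` gives 306 nM

Compound 1 has the highest number of the three in this assay. Its nearest neighbour is compound 3, with a 1.4-fold lower number from compound 1 to compound 3 (0.15 log units; within the scatter), a gap that stays within the scatter. The furthest is compound 2, with a 2.3-fold lower number from compound 1 to compound 2 (0.36 log units; beyond the scatter), a modest step that clears the scatter. Between compound 2 and compound 3 there is a 1.6-fold higher number from compound 2 to compound 3 (0.20 log units; within the scatter), again within the scatter.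

Compound 4 `Nc1ccc2cccc(OCC3CCCO3)c2n1` is not yet measured. It differs from compound 1 by (oxolan-2-yl)methyl in place of isopropyl on an oxygen on an aromatic ring.

Going by the values given here, two measured steps bear on this change. Enlarging the group on the oxygen on the aromatic ring, as in the step to pentan-3-yl, gave a 2.3-fold lower number from compound 1 to compound 2 (0.36 log units; beyond the scatter). Adding an oxygen-bearing group further along the chain, as in the step to tert-butoxy, gave a 1.4-fold lower number from compound 1 to compound 3 (0.15 log units; within the scatter). Both point toward a lower number, one modestly, one within the scatter. The new group is larger than isopropyl and also carries one hydrogen-bond acceptor, so a modest downward step is expected in this assay, a 1.6-fold lower number from compound 1 to compound 4 (0.19 log units; within the scatter), though the size is uncertain and a result within the scatter of compound 1 would not surprise.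

For compound 4 the expected value is 280 nM, with a range of 140 nM to 600 nM.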

Compound 4, half-maximal inhibitory concentration: > 2000 nM
Compound 4: no number, only a limit; the forecaster's own chance of this, stated with the estimate: 2%; middle value at least 7.1-fold (0.85 log units) from the limit.
By their numbers in this assay, from the lowest: compounds 2, 3 and 1 (each within the scatter of the next, the first and the last beyond it). At a limit, above all of these: compound 4.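

In this assay compound 4 gives > 2000 nM, which is a limit of the assay and not a number: the limit of > 2000 nM in this assay, at which 1 of the 4 values shown sits.

A larger group on this oxygen is therefore not tolerated as a matter of course: (oxolan-2-yl)methyl in place of isopropyl brings an at least 4.5-fold higher number from compound 1 to compound 4 (0.66 log units; beyond the scatter), whereas pentan-3-yl on the saturated chain carbon bound to the oxygen brought a 2.3-fold lower number from compound 1 to compound 2 (0.36 log units; beyond the scatter). An added oxygen alone does not go with such a loss either, as tert-butoxy gave a 1.4-fold lower number from compound 1 to compound 3 (0.15 log units; within the scatter), which stays within the scatter, so what sets compound 4 apart among the compounds shown is the five-membered non-aromatic ring and the absence of a branch on the carbon bound to the oxygen.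

Which of these features accounts for the step remains open, as does its full size. A cyclopentylmethyl group would keep the ring without its oxygen and a butyl chain would remove the ring altogether, so either on the same oxygen would help to separate the two features.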